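Swapping trifluoromethyl for methylsulfanyl in compound 4

The compounds below may be only part of what the source reports. "The series", "measured", "known", "first", "only" and "open" are said of these compounds alone.

Three compounds built on one shared core have been measured in a functional assay on HL-60 cells (Homo sapiens) for antiproliferative activity, with a stated time of 24 h; on this read-out higher numbers stand for weaker inhibition and lower numbers for stronger inhibition:

compound 1, `NC(=O)c1c(NC(=O)c2ccccc2Cl)sc2c1CCN(Cc1ccccc1F)C2`, gives 21800 nM
compound 2, `NC(=O)c1c(NC(=O)c2ccccc2)sc2c1CCN(C(=S)Nc1ccccc1Cl)C2`, gives 13800 nM
compound 3, `NC(=O)c1c(NC(=O)c2ccccc2C(F)(F)F)sc2c1CCN(C(=S)Nc1ccccc1Cl)C2`, gives 17600 nM

All three numbers lie within the usual scatter of one another, so none of the compounds can be called stronger or weaker than the others. Compound 3 sits closest to compound 1 and somewhat further from compound 2, but even that gap stays within the scatter.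

Compound 4, `CSc1ccccc1C(=O)Nc1sc2c(c1C(N)=O)CCN(C(=S)Nc1ccccc1Cl)C2`, has not yet been measured. It differs from compound 3 in a single place: methylsulfanyl in place of trifluoromethyl on an aromatic carbon. Among the measured compounds shown here, no measured step exchanges trifluoromethyl for methylsulfanyl, so there is no direct guide. For the measured compounds named here, the only step that touches the same aromatic carbon is a 1.3-fold higher number from compound 2 to compound 3 (0.11 log units; within the scatter), in which hydrogen was exchanged for trifluoromethyl without a shift beyond the scatter.

Because a 1.3-fold higher number from compound 2 to compound 3 (0.11 log units; within the scatter) left the number essentially unmoved, compound 4 is expected to show a step of a 1.0-fold lower number from compound 3 to compound 4 (0.02 log units; within the scatter), meaning no change beyond the scatter. Compound 4 is therefore estimated at 17000 nM, with a likely range from 7000 nM to 40000 nM.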

Compound 4, half-maximal inhibitory concentration: 30500 nM
Beside the measured number, compound 4's estimate is 1.8-fold (0.25 log units) below it; the measured number falls inside the stated range.
By their numbers in this assay, from the lowest: compounds 2, 3, 1 and 4 (each within the scatter of the next, the first and the last beyond it).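

In this assay, this position on the six-membered aromatic ring of carbon only, ortho to a large group, now has three occupants to compare: hydrogen, trifluoromethyl and methylsulfanyl. Methylsulfanyl in place of hydrogen gives a 2.2-fold higher number from compound 2 to compound 4 (0.34 log units; beyond the scatter), so this is the first change at the position to pass the scatter, and it points to modestly weaker inhibition, whereas trifluoromethyl in place of hydrogen gave only a 1.3-fold higher number from compound 2 to compound 3 (0.11 log units; within the scatter). The direct exchange gives a 1.7-fold higher number from compound 3 to compound 4 (0.24 log units; within the scatter), so methylsulfanyl and trifluoromethyl cannot be told apart here, and compound 3 stays within the scatter of both compound 2 and compound 4, which makes the position sensitive only in a small way so far. Nothing available explains why the number moves at this position.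

On these data alone, it remains open whether an amine, a carboxylic acid or a longer chain such as ethylsulfanyl at this position would move the number further in either direction, or leave it in place. As far as these compounds go, it is also open whether methylsulfanyl in place of hydrogen would give a similar step when the rest of the molecule carries other groups.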